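The compounds below may be only part of what the source reports. "The series", "measured", "known", "first", "only" and "open" are said of these compounds alone.

Compounds measured in a functional assay on SiHa cells (Homo sapiens) for inhibition, read by CCK-8 assay, with a stated time of 72 h, tested at 1 uM; on this read-out lower numbers stand for less inhibition of growth and higher numbers for more inhibition of growth at the one concentration tested:

Compound 1 `CN(C)C(=O)c1cc2cnc(Nc3ccc(NC(=O)C4(C(=O)Nc5ccccc5)CC4)cc3)nc2n1C1CCCC1`: 58%
Compound 2 `CN(C)C(=O)c1cc2cnc(Nc3ccc(NC(=O)C4(C(=O)Nc5ccccc5F)CC4)cc3)nc2n1C1CCCC1`: 63.4%

Among the compounds with values here, compound 2 gives the higher of the two numbers, but its only neighbour is compound 1, and the step of a number 5.4 percentage points higher from compound 1 to compound 2 (within the scatter) lies within the scatter, so the two compounds cannot be ordered. Compound 3 `CN(C)C(=O)c1cc2cnc(Nc3ccc(NC(=O)C4(C(=O)Nc5cccc(O)c5)CC4)cc3)nc2n1C1CCCC1` differs from compound 2 by 3-hydroxyphenyl in place of 2-fluorophenyl on an amide-type nitrogen. Within the data shown here, the one measured step, a number 5.4 percentage points higher from compound 1 to compound 2 (within the scatter), concerns the fluoro on the same ring and bears on this change only in part; it was small and within the scatter. Among the measured compounds shown here, no measured pair shows what the hydroxyl itself brings. Compound 3 is therefore expected to stay close to compound 2, with the step of a number 5.4 percentage points lower from compound 2 to compound 3 (within the scatter) not beyond the scatter. In this assay compound 3 is estimated at 58%, between 40% and 75%.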

Compound 3, percent growth inhibition at one concentration: -19.8%
Estimate against measurement, compound 3: 77.8 percentage points above; the measured number lies below the stated range.
By their numbers in this assay, from the lowest: compound 3; then compounds 1 and 2 (each within the scatter of the next).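

In this assay the ring on the amide-type nitrogen proved far from indifferent to substitution. The fluoro had left the number within the scatter, whereas adding a hydroxy to this ring gave a number 77.8 percentage points lower from compound 1 to compound 3 (beyond the scatter) and took the reading to the negative side, and the exchange of 2-fluorophenyl for 3-hydroxyphenyl gave a number 83.2 percentage points lower from compound 2 to compound 3 (beyond the scatter) of similar size. Within the data shown here, a single hydroxy is thus the only difference between compound 1 and compound 3, yet nothing available accounts for the loss.

The compounds shown leave open whether a hydroxy at another place on this ring would give a similar number. They also leave open whether a methoxy or an amine at the same place would read like the hydroxy or like the fluoro.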